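Ethoxy for cyano on the pyridine of compound 2

A few compounds are considered here, and "the series" means these few. Any claim that something is new, unique, unknown or untested is made for them only; others in the source may bear on it.

Measured compounds:
- Compound 1, `N#Cc1cncc(N2CC[C@H]3CN[C@H]3C2)c1`: 1000 nM
- Compound 2, `N#Cc1cncc(N2CC[C@@H]3CN[C@@H]3C2)c1`: 490 nM
- Compound 3, `COc1ccc(N2CC[C@H]3CN[C@H]3C2)cn1`: 1100 nM

In a functional assay on HEK293 cells for agonist activity at Neuronal acetylcholine receptor; alpha3/beta4 (Homo sapiens), read by FLIPR (a higher number here means that more compound is needed for the effect, a lower number that less compound is needed), compound 2 gives the lowest of the three numbers; its nearest neighbour is compound 1, and the step of a 2.0-fold lower number from compound 1 to compound 2 (0.31 log units; beyond the scatter) is modest but beyond the scatter, resting only on (the fact that compounds 1 and 2 differ only in the configuration as drawn). Compound 3 carries a methoxy on its pyridine in place of the cyano and has the configuration of compound 1. In this assay compound 3 gives 1100 nM. Compound 1 gives 1000 nM. These two values lie within the scatter of each other.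

Compound 4, `CCOc1cncc(N2CC[C@@H]3CN[C@@H]3C2)c1`, differs from compound 2 by ethoxy in place of cyano on an aromatic carbon. Among the compounds with values here, no measured step covers this exchange directly; the only comparison of a cyano with an alkoxy pyridine is that between compound 1 and compound 3, which shows no difference beyond the scatter. For compound 4 a step of a 1.6-fold higher number from compound 2 to compound 4 (0.21 log units; within the scatter) is therefore expected, at most a small loss. The estimate for compound 4 in this assay is 800 nM, with a range from 250 nM to 2500 nM.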

Compound 4, half-maximal effective concentration: 2800 nM
Estimate against measurement, compound 4: 3.5-fold (0.54 log units) below; measured number outside the range, above it.
By their numbers in this assay, from the lowest: compound 2; then compounds 1 and 3 (each within the scatter of the next); then compound 4.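

In this assay the step of a 5.7-fold higher number from compound 2 to compound 4 (0.76 log units; beyond the scatter) shows that this aromatic carbon, two atoms from the ring nitrogen, does not take the exchange of cyano for ethoxy as a neutral one. Within the data shown here, until now the only step in a single place was the change of configuration, a 2.0-fold lower number from compound 1 to compound 2 (0.31 log units; beyond the scatter) and this new step is the first to read the substituent itself with configuration held constant. Nothing measured in this set accounts for the size of the step.

This one pair cannot separate the removal of the nitrile from the arrival of the ethoxy. Going by these compounds, how a primary amine, a hydroxyl or a longer chain such as propoxy would read at this carbon stays open, as does whether the same exchange gives a similar step in the configuration of compound 1.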